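This account rests on a few compounds, and the source may have more. Where it says the series, first, only, none or still open, it means among the compounds named here.

In a functional assay on MGC-803 cells (Homo sapiens) for antiproliferative activity, read by MTT assay (on this read-out higher numbers stand for weaker inhibition and lower numbers for stronger inhibition), compound 1 (`COc1cc2ncnc(NCc3cccc(NC(=O)Nc4ccccc4C)c3)c2cc1OC`) gives no number, only a limit, > 50000 nM. That value is one of the two shown and sits at the limit of > 50000 nM in this assay, at which 1 of the 2 values shown sits. Going by the values given here, compound 2 (`COc1cc2ncnc(NCc3cccc(NC(=O)Nc4ccccc4Cl)c3)c2cc1OC`) gives 30200 nM in this assay, the only actual number among the two values shown. Among the compounds with values here, the sole measured step, an at least 1.6-fold lower number from compound 1 to compound 2 (0.21 log units; that floor lies within the scatter), is the only piece of evidence available. Compound 3 (`COc1cc2ncnc(NCc3cccc(NC(=O)Nc4cccc(C(F)(F)F)c4)c3)c2cc1OC`) is not yet measured; it differs from compound 2 by 3-(trifluoromethyl)phenyl in place of 2-chlorophenyl on an amide-type nitrogen. Within the data shown here, the one measured step also exchanged a substituent on the ring attached to the urea and moved the number by an amount that cannot be told from scatter, so a comparably small movement is expected here. The step of a 1.4-fold lower number from compound 2 to compound 3 (0.14 log units; within the scatter) is expected to stay within the scatter. For compound 3 the estimate in this assay is 22000 nM, with a range from 6000 nM to 60000 nM.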

Compound 3, half-maximal inhibitory concentration: > 50000 nM
Compound 3 was reported as a limit; the forecaster's own chance of this, stated with the estimate: 30%; middle value at least 2.2-fold (0.35 log units) away from the limit.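

On the amide-type nitrogen, 3-(trifluoromethyl)phenyl in place of 2-chlorophenyl gives an at least 1.6-fold higher number from compound 2 to compound 3 (0.21 log units; that floor lies within the scatter) in this assay, so the larger group brings no readable gain in inhibition, although the size of this step remains uncertain. Compound 3, like compound 1, is reported only as a limit, so the step between those two cannot be read. What is known about this position therefore rests on a single actual number, that of compound 2, while the other compounds share one limit: the limit of > 50000 nM in this assay, at which 2 of the 3 values shown sit.

The compounds shown leave open whether any group on this nitrogen can give much stronger inhibition. A phenyl ring carrying an amine or a carboxylic acid, or a longer alkyl chain in place of the ring, could help to answer this.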